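Methyl on the acid side chain of a receptor antagonist

The source may report more compounds than this note shows. Statements on the series, on what has been measured and on what is new or still open speak of the compounds shown alone.

Measured compounds:
compound 1 `O=C(O)Cn1nc(Cn2cc3cc(OCC4CC4)c(Cl)cc3n2)c2ccccc2c1=O` — 8.1 nM
compound 2 `O=C(O)Cc1nn(Cc2cn3cc(OCC4CC4)c(Cl)cc3n2)c2ccccc2c1=O` — 4.8 nM

In a functional assay on HFL1 cells for antagonist activity at sphingosine 1-phosphate receptor 2 (Homo sapiens), read by ELISA, with a stated time of 24 h (a higher number here means a weaker inhibitor, a lower number a stronger inhibitor), compound 1 gives 8.1 nM and compound 2 gives 4.8 nM. Compound 2 shows the lower of the two numbers, but the gap to compound 1 lies within the scatter, so the two compounds stand together and no order is read from them. Among the measured compounds shown here, compound 1 and compound 2 differ in more than one place, so no single step is defined between them.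

Compound 3 `C[C@H](C(=O)O)c1nn(Cc2cn3cc(OCC4CC4)c(Cl)cc3n2)c2ccccc2c1=O` is not yet measured. It differs from compound 2 by methyl in place of hydrogen on a saturated chain carbon bound to an aromatic carbon and a carbonyl carbon. For the measured compounds named here, no measured pair carries this change, so the size of the step rests on the change alone. With one carbon entering on the acid chain and the rest of compound 2 kept, a small step in this assay is expected, in either direction, and most likely none beyond the scatter. Compound 3 is therefore expected to give 6 nM, with a range from 2 nM to 20 nM. The estimated step of a 1.3-fold higher number from compound 2 to compound 3 (0.10 log units; within the scatter) reflects this expectation of little change.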

Compound 3, half-maximal inhibitory concentration: 2.1 nM
Beside the measured number, compound 3's estimate is 2.9-fold (0.46 log units) above it; low and high end bracket the measured number.
By their numbers in this assay, from the lowest: compound 3; then compounds 2 and 1 (each within the scatter of the next).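

Among the compounds shown here, compound 3 gives the first single-place step, as compound 1 and compound 2 differ in more than one place and offered no reading of any one position. In this assay, methyl in place of hydrogen on the saturated chain carbon bound to an aromatic carbon and a carbonyl carbon gives a 2.3-fold lower number from compound 2 to compound 3 (0.36 log units; beyond the scatter), a modest step, but one beyond the scatter. This position therefore accepts a carbon substituent without loss, and the change from carboxymethyl to 1-carboxyethyl goes with a lower number; no measurement among the data shown gives a reason for this step.

The compounds shown leave open how far this trend extends on the same carbon: an ethyl in place of the methyl, a second methyl on that carbon, and the opposite configuration of the 1-carboxyethyl group are all unanswered. They also leave open whether the same methyl on the acid chain of compound 1 would give a step of similar size, since one pair cannot show whether the change carries over to another core.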